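This account rests on a few compounds, and the source may have more. Where it says the series, first, only, none or still open, it means among the compounds named here.

Compound 2 `CCOC(=O)C1=Cc2ccccc2OC1(OCc1cn(CC(=O)Nc2cccc(F)c2)nn1)C(F)(F)F` carries the shared core with a trifluoromethyl group and an ethyl ester, and its side chain ends in a five-membered ring with three nitrogens. In a functional assay on MCF7 cells (Homo sapiens) for inhibition, read by MTT assay, with a stated time of 24 h (a higher number here means a weaker inhibitor, a lower number a stronger inhibitor), compound 2 gives > 150000 nM, which is a limit of the assay rather than a number. It does not stand alone there: the limit of > 150000 nM in this assay, at which 2 of the 3 values shown sit. Compound 1 `O=C(O)C1=Cc2ccccc2OC1(OCc1cc(-c2ccc(F)cc2)no1)C(F)(F)F` gives 64200 nM in this assay. Compound 3 `CCOC(=O)C1=Cc2ccccc2OC1(OCc1cc(-c2ccc(C)cc2)no1)C(F)(F)F` gives > 150000 nM, again a limit. Compound 4 `CCOC(=O)C1=Cc2ccccc2OC1(OCc1cn(-c2ccc(F)c(Cl)c2)nn1)C(F)(F)F` differs from compound 2 by 3-chloro-4-fluorophenyl in place of ((3-fluorophenyl)carbamoyl)methyl on an aromatic nitrogen. Among the compounds with values here, no measured pair shows what such a change does, so in this assay the expected step is a number no higher from compound 2 to compound 4 (the limit leaves the size open), none beyond the scatter. Compound 4 is therefore expected to give 150000 nM, within 60000 nM to 400000 nM.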

Compound 4, half-maximal inhibitory concentration: 25300 nM
Beside the measured number, compound 4's estimate is 5.9-fold (0.77 log units) above it, outside the stated range (below it).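

Replacing ((3-fluorophenyl)carbamoyl)methyl with 3-chloro-4-fluorophenyl on an aromatic nitrogen gives an at least 5.9-fold lower number from compound 2 to compound 4 (0.77 log units; beyond the scatter) in this assay, so the group at this position can change the read-out beyond the scatter. Only the lowest possible size of this step is known, since the value of compound 2 is a limit: the limit of > 150000 nM in this assay, at which 2 of the 4 values shown sit.

The compounds shown leave open whether the carbamoylmethyl link or the halogens on the phenyl ring account for the step. They also leave open what an amine or a longer chain on this aromatic nitrogen would give.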